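The source may hold more compounds than are shown below. What is called first, only, known or untested is meant among the compounds shown, and "the series" means these compounds.

Three compounds of this series have been run in a functional assay on HCT-116 cells (Homo sapiens) for inhibition, read by MTT assay, with a stated time of 2 days, tested at 10 uM; a higher number here means more inhibition at the concentration tested (going by the name of the read-out), a lower number less inhibition. Compound 1 `O=C(OCCCc1ccccc1)c1cc(-n2cc(-c3cccc(O)c3)nn2)ccc1O` gives 11%, compound 3 `O=C(O)c1cc(-n2cc(-c3cccc(O)c3)nn2)ccc1O` gives 5%, and compound 2 `COc1ccccc1-c1cn(-c2ccc(O)c(C(=O)Nc3cccc(C(F)(F)F)c3)c2)nn1` gives 61%. Among these three numbers compound 1 stands second highest; its nearest neighbour is compound 3, and the gap to compound 2 is the widest, beyond the scatter. Among the compounds with values here, the only step between two compounds that differ in a single place is a number 6 percentage points lower from compound 1 to compound 3 (within the scatter), a change at the oxygen next to the carbonyl group that moves nothing beyond the scatter. Compound 2 differs from compound 1 in more than one place, so its higher number cannot be tied to any one change.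

Compound 4 `COc1ccc(-c2cn(-c3ccc(O)c(C(=O)OCCCc4ccccc4)c3)nn2)cc1` differs from compound 1 by 4-methoxyphenyl in place of 3-hydroxyphenyl on an aromatic carbon. Within the data shown here, no measured step bears directly on this change: the one step in hand, from compound 1 to compound 3, concerns a different part of the molecule and lies within the scatter, and no measured pair isolates the aryl group on the five-membered aromatic ring with 3 nitrogen. With nothing pointing either way, the expected step for compound 4 is a number 5 percentage points higher from compound 1 to compound 4 (within the scatter), not beyond the scatter. Compound 4 is therefore estimated at 16%, with a range from 3% to 38%.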

Compound 4, a percentage reported as inhibition, at one concentration (the size of the read-out at that concentration, not a potency): 12%
Compound 4: middle estimate off by 4 percentage points, on the high side; the measured number falls inside the stated range.
By their numbers in this assay, from the lowest: compounds 3, 1 and 4 (each within the scatter of the next); then compound 2.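

Within the data shown here, at the aromatic carbon of the five-membered aromatic ring with 3 nitrogen, the aryl group now has a step of its own in this assay, where the earlier compounds offered only a change at the oxygen next to the carbonyl group: with 4-methoxyphenyl in place of 3-hydroxyphenyl, the result is a number 1 percentage points higher from compound 1 to compound 4 (within the scatter). This swap takes the aryl group from 1 hydrogen-bond donor to 0 and adds one heavy atom, and with the 3-phenylpropyl ester held constant, neither difference comes with a shift beyond the scatter. No measurement at hand explains this outcome, and the reading rests on this single pair.

Still open, from the compounds shown here alone, is whether an amine or a carboxylic acid on the phenyl ring at this position would give a step beyond the scatter, or whether a longer chain between the triazole-bearing carbon and the phenyl ring would do so. Also open, going by these compounds, is whether the same aryl swap would read the same way with the amide of compound 2 in place of the 3-phenylpropyl ester.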